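The source may report more compounds than this note shows. Statements on the series, on what has been measured and on what is new or still open speak of the compounds shown alone.

Working notes on the series. The central read-out is a functional assay on the whole organism (Central nervous system) for activation, with Mus musculus as the target; on this read-out lower numbers stand for an effect already at smaller amounts and higher numbers for an effect only at larger amounts of compound. Compound 1 `O=C1CCC2(c3ccc(F)cc3)OCCCN12` gives in this assay 75 mg/kg. The open-chain analogue compound 3 `O=C(CCC(=O)c1ccc(Cl)cc1)NCCCO` gives 300 mg/kg in this assay. Compound 2 `Cc1ccc(C23CCC(=O)N2CCCO3)c(C)c1` is the reference for the step considered here; its result in this assay is a limit of the method rather than a number, < 50 mg/kg, so where compound 2 stands on the scale is known only as a bound, as noted in the limit of < 50 mg/kg in this assay, at which 1 of the 3 values shown sits. Among the measured compounds shown here, no pair of measured compounds differs in a single place, so no measured step is available to calibrate the change.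

The unmeasured compound 4 `Cc1ccc(C23CCC(=O)N2CCCO3)cc1` differs from compound 2 by hydrogen in place of methyl on an aromatic carbon. With no measured step of this kind in hand and a reference that is itself a limit, only a small shift is expected in this assay, and none that should clearly exceed the usual scatter; the step of an at least 1.2-fold higher number from compound 2 to compound 4 (0.07 log units; that floor lies within the scatter) is an estimate set close to the reference. Compound 4 is accordingly expected to give about 60 mg/kg in this assay, within a range from 30 mg/kg to 120 mg/kg, with a fair chance that the assay again reports only a limit.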

Compound 4, dose for half-maximal effect: < 50 mg/kg
Compound 4 was reported as a limit; the forecaster's own chance of this, stated with the estimate: 35%; middle value at least 1.2-fold (0.07 log units) from the limit.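

For compound 4, this assay again returns a limit of the assay and not a number, < 50 mg/kg, so taking away this methyl group does not lift the result off that limit. The step for hydrogen in place of methyl on an aromatic carbon cannot be read, because the compounds on both sides of it stand at a limit: the limit of < 50 mg/kg in this assay, at which 2 of the 4 values shown sit.

Among the compounds shown here, compound 4 does give the first readable step, an at least 1.5-fold lower number from compound 1 to compound 4 (0.17 log units; that floor lies within the scatter), for methyl in place of fluoro on an aromatic carbon, although its printed floor does not clear the usual scatter.

As far as these compounds go, how far compound 2 and compound 4 really lie from each other, and so whether this methyl group has any effect on the read-out, remains open while both stay limits. Also open, from the compounds shown here alone, is how a methoxy group or an amine on this aromatic carbon would read in this assay, and whether either would give a number rather than another limit.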